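The compounds below may be only part of what the source reports. "The series", "measured", "known", "first", "only" and "open" are said of these compounds alone.

Three amides built on a shared core have been tested in a functional assay on BXPC-3 cells (Homo sapiens) for antiproliferative activity, read by MTT assay, with a stated time of 24 h; on this read-out lower numbers stand for stronger inhibition and higher numbers for weaker inhibition. Compound 1, `CCn1c(C(=O)N[C@H](C)C(=O)OC)ccc1C(CC)(CC)c1ccc(OCS(=O)(=O)c2ccccc2)c(C)c1`, gives only a limit of the assay, > 50000 nM, and not a number. Compound 2, `CCn1c(C(=O)NCCNC(=O)OC(C)(C)C)ccc1C(CC)(CC)c1ccc(OCS(=O)(=O)c2ccccc2)c(C)c1`, likewise gives only a limit, > 50000 nM. Compound 3, `CCn1c(C(=O)N[C@@H](C)CO)ccc1C(CC)(CC)c1ccc(OCS(=O)(=O)c2ccccc2)c(C)c1`, is the only one of the three with an actual number, 15300 nM.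

The two measured steps that reach it are an at least 3.2-fold lower number from compound 1 to compound 3 (0.51 log units; beyond the scatter) and an at least 3.2-fold lower number from compound 2 to compound 3 (0.51 log units; beyond the scatter). From the compounds shown here alone, each replaces the whole group on the amide-type nitrogen, and each starts from a limit, so its true size remains open.

Compound 4, `CCn1c(C(=O)N[C@H](CO)C(C)C)ccc1C(CC)(CC)c1ccc(OCS(=O)(=O)c2ccccc2)c(C)c1`, keeps the 1-(hydroxymethyl)ethyl skeleton of compound 3 but extends it: isopropyl in place of methyl on a saturated chain carbon bound to an amide-type nitrogen and a saturated chain carbon. That is isopropyl in place of methyl on a saturated chain carbon bound to an amide-type nitrogen and a saturated chain carbon. Neither measured step changes this methyl alone, so neither gives a direct size for the new change.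

The best anchor is therefore compound 3 at 15300 nM, and no shift beyond the scatter is expected in this assay, though the uncertainty is wide in both directions. The estimated step is a 1.1-fold lower number from compound 3 to compound 4 (0.04 log units; within the scatter). The expected value for compound 4 is 14000 nM, with an estimated range of 5000 nM to 45000 nM.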

Compound 4, half-maximal inhibitory concentration in the BXPC-3 assay: 7720 nM
Compound 4: the middle estimate sits 1.8-fold (0.26 log units) above what was measured; the range from low to high includes it.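

In the BXPC-3 assay, compound 3 gives 15300 nM and compound 4 gives 7720 nM. In the BXPC-3 assay, the swap of methyl for isopropyl on a saturated chain carbon bound to an amide-type nitrogen and a saturated chain carbon is a 2.0-fold lower number from compound 3 to compound 4 (0.30 log units; within the scatter), so the two compounds cannot be told apart and this carbon carries the larger branched group with no readable change. The earlier steps shown here did not show this; each replaced the whole group on the nitrogen. In the BXPC-3 assay, the steps of an at least 6.4-fold lower number from compound 2 to compound 4 (0.81 log units; beyond the scatter) and an at least 6.4-fold lower number from compound 1 to compound 4 (0.81 log units; beyond the scatter) lie beyond the scatter, but each starts from a limit of the assay and so gives only a minimum size: the limit of > 50000 nM in the BXPC-3 assay, at which 2 of the 4 values shown sit. In a physicochemical assay for solubility, read by HPLC, at pH 7.4 (on this read-out lower numbers stand for lower solubility and higher numbers for higher solubility), compound 3 gives 35.7 ug/mL and compound 4 gives 27.8 ug/mL. In the physicochemical assay, the same swap of methyl for isopropyl is a 1.3-fold lower number from compound 3 to compound 4 (0.11 log units; within the scatter), so the two compounds cannot be told apart on solubility either.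

From the compounds shown here alone, with only methyl and isopropyl compared at this carbon, it remains open whether a longer chain such as n-butyl, or a phenyl ring, would move the number beyond the scatter. Going by these compounds, it is also open what happens to activity if the hydroxyl of the 1-(hydroxymethyl)-2-methylpropyl group gives way to an amine or a carboxylic acid.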